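Compound 3 to compound 4: phenyl to 4-methylphenyl

A few compounds are considered here, and "the series" means these few. Any claim that something is new, unique, unknown or untested is made for them only; others in the source may bear on it.

Measured in a functional assay on OVCAR-3 cells (Homo sapiens) for inhibition, read by sulforhodamine B assay, with a stated time of 48 h; on this read-out lower numbers stand for stronger inhibition of growth and higher numbers for weaker inhibition of growth:
- compound 1 `Cc1nnc(-c2nn(-c3ccccc3)c(-c3ccccc3)c2C#N)c2cn(-c3ccccc3)nc12`: 96800 nM
- compound 2 `N#Cc1c(-c2nnc(O)c3nn(-c4ccccc4)cc23)nn(-c2ccccc2)c1-c1ccccc1`: > 100000 nM (a limit of the assay)
- compound 3 `N#Cc1c(-c2nnc(-c3ccccc3)c3nn(-c4ccccc4)cc23)nn(-c2ccccc2)c1-c1ccccc1`: 93800 nM

Among the measured compounds shown here, compound 3 at 93800 nM and compound 1 at 96800 nM lie within the scatter of each other, and these are the only two true numbers in the set. Compound 2 gives > 100000 nM, which is a limit and not a number.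

The next compound is compound 4 `Cc1ccc(-n2cc3c(-c4nn(-c5ccccc5)c(-c5ccccc5)c4C#N)nnc(-c4ccccc4)c3n2)cc1`. The change is methyl in place of hydrogen on an aromatic carbon, so that phenyl becomes 4-methylphenyl.

For the measured compounds named here, no measured step touches this ring. The nearest evidence is replacement at another aromatic carbon: a 1.0-fold lower number from compound 1 to compound 3 (0.01 log units; within the scatter), with phenyl in place of methyl. The two steps through compound 2 are bounded only by its limit: an at least 1.0-fold higher number from compound 1 to compound 2 (0.01 log units; that floor lies within the scatter) and an at least 1.0-fold lower number from compound 2 to compound 3 (0.02 log units; that floor lies within the scatter). Going by the values given here, since the one numeric step, a 1.0-fold lower number from compound 1 to compound 3 (0.01 log units; within the scatter), stays within the scatter, no shift beyond the scatter is expected in this assay. The expected change is a 1.0-fold lower number from compound 3 to compound 4 (0.02 log units; within the scatter). Compound 4 could also be reported only as a limit, given (the limit of > 100000 nM in this assay, at which 1 of the 3 values shown sits).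

For compound 4 the estimated value is 90000 nM, with an expected range of 45000 nM to 100000 nM.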

Compound 4, concentration for 50% growth inhibition: > 100000 nM
Compound 4 was reported as a limit; the forecaster's own chance of this, stated with the estimate: 35%; at least 1.1-fold (0.04 log units) between middle value and limit.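

In this assay compound 4 gives > 100000 nM, which is a limit of the assay and not a number. Among the compounds shown here, this is the first change on this ring, with methyl on an aromatic carbon para to a large group, and it reads as an at least 1.0-fold higher number from compound 3 to compound 4 (0.02 log units; that floor lies within the scatter), so the data show no shift beyond the scatter and leave the true size of the step unknown. Compared with the earlier compounds, the result adds a second compound at the limit, leaving only compound 1 and compound 3 with true numbers to compare: the limit of > 100000 nM in this assay, at which 2 of the 4 values shown sit.

Still open, going by these compounds, is whether any group at this place gives a true number clearly lower than that of compound 3 in this assay, for example an amine, a carboxylic acid or a longer chain in place of the methyl. Also open is whether the lack of a clear shift holds for substitution on the other phenyl rings of the shared core, as the compounds shown vary only this ring and one other aromatic carbon.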